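The source may report more compounds than this note shows. Statements on the series, on what has been measured and on what is new or still open speak of the compounds shown alone.

Measured so far:
compound 1 `COCc1cc(C(C)=O)c(O)cc1OCCCCCCC#N` — 47%
compound 2 `C=CCc1cc(C(C)=O)c(O)cc1OCCCCCC#N` — 81%

Both values come from an assay on isolated protein for inhibition of leukotriene B4 receptor 1 (Homo sapiens), tested at 10 uM; on this read-out higher numbers stand for more inhibition at the one concentration tested (going by the name of the read-out) and lower numbers for less inhibition. Compound 2 stands highest of the two numbers; the nearest is compound 1, whose number lies lower by a gap beyond the usual scatter. Going by the values given here, the two structures differ in more than one place, so no single step connects them.

Compound 3 `C=CCc1cc(C(C)=O)c(O)cc1OCCCC` has not yet been measured in this assay. It differs from compound 2 as follows: hydrogen in place of cyanomethyl on a saturated chain carbon, four bonds along the chain from an oxygen on an aromatic ring. Among the compounds with values here, no measured pair shows this change, so its size is unknown; a downward step is expected, and the step expected here reads a number 26 percentage points lower from compound 2 to compound 3 (beyond the scatter). For compound 3 the expected result in this assay is 55%, with a range from 30% to 80%.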

Compound 3, a percentage reported as inhibition, at one concentration (the size of the read-out at that concentration, not a potency): 32%
Compound 3: middle estimate off by 23 percentage points, on the high side; the range from low to high includes it.
By their numbers in this assay, from the lowest: compound 3; then compound 1; then compound 2.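

Hydrogen in place of cyanomethyl gives a number 49 percentage points lower from compound 2 to compound 3 (beyond the scatter) in this assay, the only single-place step in the series so far. The read-out therefore depends strongly on what sits on this saturated chain carbon, four bonds along the chain from an oxygen on an aromatic ring. No evidence on hand explains the size of this step.

As far as these compounds go, whether the step follows the nitrile itself or the lost chain length remains open. A plain longer chain, an amine or a carboxylic acid in place of cyanomethyl would help separate the two.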